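Fluorine moved on the benzyl of a pyridone kinase series

The source may report more compounds than this note shows. Statements on the series, on what has been measured and on what is new or still open speak of the compounds shown alone.

Measured compounds:
Compound 1, `Nc1n[nH]c2cc(-c3ccc(=O)n(Cc4ccccc4F)c3)ccc12`: 4 nM
Compound 2, `O=c1ccc(-c2ccc3cn[nH]c3c2)cn1Cc1cccc(F)c1`: 38 nM

In an assay for inhibition of MAP kinase-interacting serine/threonine-protein kinase 2 (Homo sapiens), read by luminescence and ADP-Glo, with a stated time of 2 h (on this read-out lower numbers stand for stronger inhibition and higher numbers for weaker inhibition), compound 1 gives 4 nM. Going by the values given here, compound 2 stands at the higher of the two numbers, with 38 nM in this assay; compound 1 is its only neighbour, and the gap between the two lies beyond the scatter. Compound 1 and compound 2 differ in more than one place, so the numbers say nothing about any single change.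

Compound 3, `O=c1ccc(-c2ccc3cn[nH]c3c2)cn1Cc1ccccc1F`, has not yet been measured in this assay. It differs from compound 2 in one place: 2-fluorophenyl in place of 3-fluorophenyl on a saturated chain carbon bound to an aromatic nitrogen. The two have the same atoms, joined differently.

Among the compounds with values here, no pair of measured compounds shows this change on its own, so the size of the step has no precedent here. Compound 1 does carry the 2-fluorophenyl, but its core also differs, so nothing can be read from it for this step alone. The step from compound 2 to compound 3 is therefore expected to be small, a 1.5-fold lower number from compound 2 to compound 3 (0.18 log units; within the scatter), and not clearly beyond the scatter. Compound 3 is estimated at 25 nM, within 8 nM to 80 nM.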

Compound 3, half-maximal inhibitory concentration: 37 nM
Compound 3: the middle estimate sits 1.5-fold (0.17 log units) below what was measured, within the range that was stated.
By their numbers in this assay, from the lowest: compound 1; then compounds 3 and 2 (each within the scatter of the next).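

Exchanging 3-fluorobenzyl for 2-fluorobenzyl on the shared core gives, in this assay, a 1.0-fold lower number from compound 2 to compound 3 (0.01 log units; within the scatter), so the two placements of fluorine cannot be told apart in this assay on this core. Compound 3 also supplies the single-place comparison that compound 1 and compound 2 could not give: with 2-fluorobenzyl held constant, hydrogen in place of amino on an aromatic carbon gives a 9.3-fold higher number from compound 1 to compound 3 (0.97 log units; beyond the scatter), a step that stands clear of the scatter. Among these compounds, then, the one-place difference that separates the numbers is the amino group and not the position of fluorine, although nothing measured here accounts for either step.

The compounds shown leave open whether the benzyl position would remain as undiscriminating with chlorine or a methoxy group in place of fluorine, or with a benzyl that carries no fluorine at all. They also leave open whether 3-fluorobenzyl and 2-fluorobenzyl would still match on the core of compound 1, and whether a methylamino or hydroxyl group could stand in for the amino group.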